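Lengthening the chain again: compound 2 to compound 3

The source may report more compounds than this note shows. Statements on the series, on what has been measured and on what is new or still open speak of the compounds shown alone.

Compound 1, `CCCCCCCCNC[C@@H]1OC[C@H](N)[C@@H]1O`, gives in a functional assay on B16-F10 cells (Mus musculus) for antiproliferative activity, read by MTT assay, with a stated time of 72 h (a lower number here means a stronger inhibitor, a higher number a weaker inhibitor), only a limit, > 128000 nM.
Compound 2, `CCCCCCCCCCCCNC[C@@H]1OC[C@H](N)[C@@H]1O`, gives in this assay the value 10700 nM.

Among the measured compounds shown here, compound 2 thus holds the only real number here; the other entry is a limit (the limit of > 128000 nM in this assay, at which 1 of the 2 values shown sits). Compound 3, `CCCCCCCCCCCCCCNC[C@@H]1OC[C@H](N)[C@@H]1O`, differs from compound 2 by ethyl in place of hydrogen on a saturated chain carbon, ten or more bonds along the chain from an amine nitrogen. For the measured compounds named here, the one measured step that bears on this, an at least 11-fold lower number from compound 1 to compound 2 (1.07 log units; beyond the scatter), is a large drop for a longer chain. The present change is shorter, so a smaller drop is expected, a 1.8-fold lower number from compound 2 to compound 3 (0.25 log units; within the scatter). Compound 3 is therefore estimated at 6000 nM, between 2000 nM and 25000 nM.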

Compound 3, half-maximal inhibitory concentration: 14300 nM
For compound 3 the middle estimate is 2.4-fold (0.38 log units) below the measured one; the range from low to high includes it.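

In this assay, ethyl in place of hydrogen on this saturated chain carbon gives a 1.3-fold higher number from compound 2 to compound 3 (0.13 log units; within the scatter), so the large drop seen with the earlier lengthening does not carry on at this position. Compound 3 still shows an at least 8.9-fold lower number from compound 1 to compound 3 (0.95 log units; beyond the scatter) when set against the shortest chain shown. That step has no exact size, since compound 1 gives only a limit: the limit of > 128000 nM in this assay, at which 1 of the 3 values shown sits.

From the compounds shown here alone, whether a still longer chain would change the number beyond the scatter remains open. So does the effect of a carboxylic acid or an amine at the far end of the chain.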